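The source may report more compounds than this note shows. Statements on the series, on what has been measured and on what is new or still open speak of the compounds shown alone.

Working notes on the series. In an in vitro ADME assay on microsomes from liver (Canis lupus familiaris) for metabolic stability, tested at 1 uM (a higher number here means that the compound lasts longer, a lower number that the compound disappears faster), compound 1 `COc1cc2nc(N3CCCN(C(=O)N4CCOCC4)CC3)nc(N)c2c(-c2ccccn2)c1OC` gives 0.767 h, and in this assay compound 2 `COc1cc2nc(N3CCCN(C(=O)N4CCOCC4)CC3)cc(N)c2c(-c2ccccc2)c1OC` gives 0.417 h; the two numbers sit within the usual scatter of each other, so compound 2 stands alongside compound 1 rather than apart from it. Compound 3 `COc1cc2nc(N3CCCN(C(=O)N4CCOCC4)CC3)cc(N)c2c(-c2ccc(F)cc2)c1OC` is not yet measured in this assay; it differs from compound 2 by fluoro in place of hydrogen on an aromatic carbon. Within the data shown here, no measured step of this kind is available, so the step from compound 2 to compound 3 in this assay is expected to stay within the scatter, a 1.2-fold higher number from compound 2 to compound 3 (0.08 log units; within the scatter). For compound 3 in this assay the estimate is 0.5 h, with a range of 0.25 h to 1 h.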

Compound 3, half-life in the liver assay: 0.5 h
Estimate against measurement, compound 3: no gap at the digits printed; measured number inside the range.
By their numbers in the liver assay, from the lowest: compounds 2, 3 and 1 (each within the scatter of the next).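

The para position of the phenyl ring now has a first measured step: phenyl to 4-fluorophenyl reads in the liver assay as (a 1.2-fold higher number from compound 2 to compound 3 (0.08 log units; within the scatter)). In a physicochemical assay for lipophilicity, in phosphate buffer, at pH 7.4 (a lower number here means a more polar compound, a higher number a more lipophilic compound), compound 2 gives 1.8 and compound 3 gives 1.8, and the same change reads as (no change at the digits printed from compound 2 to compound 3 (within the scatter)). Nothing available bears on the cause of either result. Still open, going by these compounds, is whether a different group at this carbon, such as an amine or a carboxylic acid, would give a step beyond the scatter in either assay. Also open, on these data alone, is whether fluoro in place of hydrogen reads the same on another core.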